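Compound 3 to compound 4: aryl to cyclopropyl

The source may hold more compounds than are shown below. What is called first, only, known or untested is meant among the compounds shown, and "the series" means these compounds.

Values in an ADME assay on microsomes from liver (Homo sapiens) for metabolic stability, with a stated time of 10 min; on this read-out lower numbers stand for a less stable compound and higher numbers for a more stable compound:
- compound 1 `CC(=O)N1CC[C@@H](C(=O)N2CC[C@](c3ccc(C(OCc4c(F)cccc4F)(C(F)(F)F)C(F)(F)F)cc3)(S(=O)(=O)c3ccc(F)cc3)C2)C1` gives 9%
- compound 2 `Cc1cccc(C)c1COC(c1ccc([C@]2(S(=O)(=O)c3ccc(F)cc3)CCN(C(=O)[C@H]3CC[C@H](C(=O)O)CC3)C2)cc1)(C(F)(F)F)C(F)(F)F` gives 89%
- compound 3 `Cc1cccc(F)c1COC(c1ccc([C@]2(S(=O)(=O)c3ccc(F)cc3)CCN(C(=O)[C@H]3CC[C@H](C(=O)O)CC3)C2)cc1)(C(F)(F)F)C(F)(F)F` gives 79%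

Compound 3 at 79% lies within the scatter of compound 2 at 89% and far above compound 1 at 9%. Compound 4 `O=C(O)[C@H]1CC[C@H](C(=O)N2CC[C@](c3ccc(C(OCC4CC4)(C(F)(F)F)C(F)(F)F)cc3)(S(=O)(=O)c3ccc(F)cc3)C2)CC1` carries cyclopropyl in place of 2-fluoro-6-methylphenyl on a saturated chain carbon bound to an oxygen on a saturated carbon. For the measured compounds named here, the only measured step, a number 10 percentage points lower from compound 2 to compound 3 (within the scatter), is fluoro in place of methyl on an aromatic carbon. Going by the values given here, it is a much smaller exchange, and no measured pair covers this one, so the guidance is weak. No step beyond the scatter is expected in this assay. The expected step is a number 4 percentage points lower from compound 3 to compound 4 (within the scatter). Compound 4 is estimated at 75%, with an expected range of 50% to 92%.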

Compound 4, percent of the compound remaining: 75%
Estimate against measurement, compound 4: no gap at the digits printed, and the stated range covers the measured number.
By their numbers in this assay, from the lowest: compound 1; then compounds 4, 3 and 2 (each within the scatter of the next, the first and the last beyond it).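

In this assay, cyclopropyl in place of 2-fluoro-6-methylphenyl gives a number 4 percentage points lower from compound 3 to compound 4 (within the scatter), so at this place the aromatic ring can be exchanged for a much smaller carbon ring without a step beyond the scatter. Measured against 2,6-dimethylphenyl, the same kind of exchange gives a number 14 percentage points lower from compound 2 to compound 4 (beyond the scatter), so the reading depends on the compound of comparison. No measurement available here accounts for either step.

Still open, from the compounds shown here alone, is how a longer alkyl chain or an amine would read on this saturated chain carbon. Also open, going by these compounds, is whether cyclopropyl would read the same on the core of compound 1.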